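The source may report more compounds than this note shows. Statements on the series, on what has been measured and on what is new or still open speak of the compounds shown alone.

Measured compounds in a functional assay on EL4 cells (Mus musculus) for inhibition, tested at 100 uM; on this read-out higher numbers stand for more inhibition at the one concentration tested (going by the name of the read-out) and lower numbers for less inhibition:
- compound 1, `OC[C@H]1O[C@@H](n2cnc3c(NCc4ccccc4)nccc32)C[C@@H]1O`: 8%
- compound 2, `[N-]=[N+]=Nc1nccc2c1ncn2[C@H]1C[C@H](O)[C@@H](CO)O1`: 13%
- compound 3, `CSc1nccc2c1ncn2[C@H]1C[C@H](O)[C@@H](CO)O1`: < 5%

All three compounds share the same sugar-bearing core and differ only in the group on one aromatic carbon. Compound 1 carries benzylamino there, compound 2 azido, compound 3 methylsulfanyl. The readings are a number 5 percentage points higher from compound 1 to compound 2 (within the scatter) and a number at least 3 percentage points lower from compound 1 to compound 3 (that floor lies within the scatter), and a number at least 8 percentage points lower from compound 2 to compound 3 (that floor lies within the scatter). For compound 3 the value < 5% is a limit of the assay and not a number, so compound 3 stands at the limit of < 5% in this assay, at which 1 of the 3 values shown sits.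

Compound 4, `OC[C@H]1O[C@@H](n2cnc3c(SCc4ccccc4)nccc32)C[C@@H]1O`, is the next compound to be measured. It differs from compound 3 by phenyl in place of hydrogen on a saturated chain carbon bound to a sulfur. Among the compounds with values here, none of the measured steps concerns such a change; they all swap the whole group on the aromatic carbon rather than extend the methyl on sulfur. Compound 1, which also carries a benzyl group, gives 8%, and no pair shown moves beyond the scatter. The step of a number at least 2 percentage points higher from compound 3 to compound 4 (that floor lies within the scatter) is therefore expected to stay within the scatter. Compound 4 is estimated at 7%, within 0% to 16%.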

Compound 4, a percentage reported as inhibition, at one concentration (the size of the read-out at that concentration, not a potency): 11%
The estimate for compound 4 lay 4 percentage points below the measured number; the measured number falls inside the stated range.
By their numbers in this assay, from the lowest: compounds 1, 4 and 2 (each within the scatter of the next). At a limit, below all of these: compound 3.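

In this assay, the change from methylsulfanyl to benzylsulfanyl, which extends the group on sulfur rather than swapping the whole group on the aromatic carbon, gives a number at least 6 percentage points higher from compound 3 to compound 4 (that floor lies within the scatter). The size of this step is only a floor, since compound 3 is a limit and not a number: the limit of < 5% in this assay, at which 1 of the 4 values shown sits. Benzylsulfanyl in place of benzylamino gives a number 3 percentage points higher from compound 1 to compound 4 (within the scatter), and benzylsulfanyl in place of azido gives a number 2 percentage points lower from compound 2 to compound 4 (within the scatter), so neither swap separates these compounds at this position.

From the compounds shown here alone, whether a carboxylic acid on the aromatic carbon, or a longer chain such as phenylethyl on sulfur, would move the reading beyond the scatter stays open. Potency also stays open: each compound has a reading at one concentration only.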